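The compounds below may be only part of what the source reports. "The series", "measured", "known", "first", "only" and "open" are said of these compounds alone.

Compound 1 `Cc1ccc(NC(=O)Nc2cccc(NC(=O)c3ccccn3)c2)cc1`: 20 nM
Compound 2 `O=C(NCc1ccccc1)Nc1cccc(NC(=O)c2ccccn2)c1`: 2990 nM
Compound 3 `O=C(CSC(=S)N1CCOCC1)Nc1cccc(NC(=O)c2ccccn2)c1`: 50 nM

All three values come from a functional assay on A549 cells (Homo sapiens) for antiproliferative activity, read by MTT assay, with a stated time of 48 h; a lower number here means a stronger inhibitor, a higher number a weaker inhibitor. Of the three numbers, compound 3 holds the second highest at 50 nM. It sits much nearer to compound 1, at 20 nM, than to compound 2, at 2990 nM.

Compound 4 `CCN1CCN(C(=S)SCC(=O)Nc2cccc(NC(=O)c3ccccn3)c2)CC1` differs from compound 3 in one place: 4-ethylpiperazin-1-yl in place of morpholin-4-yl on a thiocarbonyl carbon. Here, 4-ethylpiperazin-1-yl stands in place of morpholin-4-yl on a thiocarbonyl carbon, and each group is a six-membered non-aromatic ring with 2 hetero atoms.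

Among the compounds with values here, only one measured step is available, a 150-fold higher number from compound 1 to compound 2 (2.17 log units; beyond the scatter), and it is large. It comes from benzyl in place of 4-methylphenyl on an amide-type nitrogen, not from a change on the thiocarbonyl carbon. It therefore shows that a single change can matter greatly in this small set, but it does not set the size of this step. Within the data shown here, no measured pair varies the group on the thiocarbonyl carbon, so no step beyond the scatter is expected in this assay, and no direction is favoured.

The estimate amounts to an expected 1.3-fold lower number from compound 3 to compound 4 (0.10 log units; within the scatter). For compound 4 the expected value is 40 nM, with an estimated range from 10 nM to 160 nM.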

Compound 4, half-maximal inhibitory concentration: 3720 nM
Estimate against measurement, compound 4: 93-fold (1.97 log units) below, outside the stated range (above it).
By their numbers in this assay, from the lowest: compound 1; then compound 3; then compounds 2 and 4 (each within the scatter of the next).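

In this assay, the group on the thiocarbonyl carbon proves to matter greatly: 4-ethylpiperazin-1-yl in place of morpholin-4-yl gives a 74-fold higher number from compound 3 to compound 4 (1.87 log units; beyond the scatter) and takes compound 4 out of the range of compound 1 and compound 3. Within the data shown here, no earlier pair varied this place, and this large step shows that even an exchange between two six-membered non-aromatic rings, each with 2 hetero atoms and with the same counts of hydrogen-bond donors and acceptors, can have a large effect; what differs in the counts is 8 heavy atoms against 6, and two nitrogens against one nitrogen and one oxygen. Nothing given here accounts for the size of this step.

The compounds shown leave open whether the step goes with the ethyl group, with the second ring nitrogen or with the loss of the ring oxygen. Piperidin-1-yl, piperazin-1-yl or 4-methylpiperazin-1-yl on the same thiocarbonyl carbon would begin to separate these possibilities, and whether any group here matches morpholin-4-yl remains unknown.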